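Debromination at the furan-bearing core: expected metabolic stability

The compounds below may be only part of what the source reports. "The series", "measured", "known", "first", "only" and "open" are said of these compounds alone.

Measured so far:
compound 1 `CCCNC(=O)C1CCN(C(=O)c2cc3oc(Br)cc3n2Cc2ccc(OC)cc2)CC1` — 0.158 h
compound 2 `CCCNC(=O)C1CC12CCN(C(=O)c1cc3sc(Br)nc3n1Cc1ccc(OC)cc1)CC2` — 0.0828 h
compound 3 `CCCNC(=O)[C@@H]1C[C@H]2CCC[C@@H](C1)[C@@H]2NC(=O)c1cc2scnc2n1Cc1ccc(OC)cc1` — 0.743 h

In an ADME assay on microsomes from liver (Homo sapiens) for metabolic stability (a lower number here means that the compound disappears faster, a higher number that the compound lasts longer), compound 1 gives 0.158 h, the second highest of the three numbers. Compound 2 gives 0.0828 h, which lies within the scatter of compound 1, so the two cannot be ordered. Going by the values given here, compound 3 gives 0.743 h, beyond the scatter above compound 1; with only three compounds, none of them differing in one place, no pattern can be drawn from this.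

Compound 4 `CCCNC(=O)C1CCN(C(=O)c2cc3occc3n2Cc2ccc(OC)cc2)CC1` differs from compound 1 in one place: hydrogen in place of bromo on an aromatic carbon. Among the compounds with values here, no measured pair shows this change, so nothing in the data gives its size or direction. The expectation is a small step, a 1.3-fold lower number from compound 1 to compound 4 (0.12 log units; within the scatter), not clearly beyond the scatter and if anything downward. Compound 4 is therefore expected to give about 0.12 h in this assay, with a likely range from 0.05 h to 0.3 h.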

Compound 4, half-life: 0.0457 h
Beside the measured number, compound 4's estimate is 2.6-fold (0.42 log units) above it; the whole stated range lies above it.
By their numbers in this assay, from the lowest: compounds 4, 2 and 1 (each within the scatter of the next, the first and the last beyond it); then compound 3.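

In this assay, going by these compounds alone, hydrogen in place of bromo on this aromatic carbon, next to the ring oxygen, gives a 3.5-fold lower number from compound 1 to compound 4 (0.54 log units; beyond the scatter) and is the first change that can be read in one place. With the rest of the structure the same, this position is shown to matter for the read-out, and the compound with bromo gives the higher number.

This single pair does not show whether a step of this size would appear with the same change on the core of compound 2, which also carries bromo. It also leaves open how other groups at this position, such as chloro, methyl or nitrile, would compare with bromo and hydrogen.

No supporting data shown here bear on why this step occurs.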